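Methyl and ring-size steps in an amide-linked series

A few compounds are considered here, and "the series" means these few. Any claim that something is new, unique, unknown or untested is made for them only; others in the source may bear on it.

Measured so far in a functional assay on HT-29 cells (Homo sapiens) for cytotoxicity, read by MTT assay, with a stated time of 72 h; on this read-out lower numbers stand for stronger inhibition and higher numbers for weaker inhibition:

compound 1, `COc1cc2c(Oc3ccc(NC(=O)c4cc(-c5ccccc5)ccn4)cc3F)ccnc2cc1OCCCN1CCCC1`: 120 nM
compound 2, `COc1cc2c(Oc3ccc(NC(=O)c4cc(-c5ccc(C)cc5)ccn4)cc3F)ccnc2cc1OCCCN1CCCC1`: 350 nM
compound 3, `COc1cc2c(Oc3ccc(NC(=O)c4cc(-c5ccccc5)ccn4)cc3F)ccnc2cc1OCCCN1CCCCC1`: 270 nM

Two single-point changes have been measured. Adding methyl, (methyl in place of hydrogen on an aromatic carbon), gives a 2.9-fold higher number from compound 1 to compound 2 (0.46 log units; beyond the scatter). Changing the amine ring, (piperidin-1-yl in place of pyrrolidin-1-yl on a saturated chain carbon, three bonds along the chain from an oxygen on an aromatic ring), gives a 2.3-fold higher number from compound 1 to compound 3 (0.35 log units; beyond the scatter). Compound 2 and compound 3 lie within the scatter of each other, so no order between them is read.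

Compound 4, `COc1cc2c(Oc3ccc(NC(=O)c4cc(-c5ccc(C)cc5)ccn4)cc3F)ccnc2cc1OCCCN1CCCCC1`, is not yet measured. It carries the same change as compound 2 does relative to compound 1, now on the core of compound 3: methyl in place of hydrogen on an aromatic carbon. The place is the same word for word in both cases, so this is treated as the same change. The cores of compound 3 and compound 4 differ from those of compound 1 and compound 2 by the ring-size change given above.

With one instance of the methyl step to go on, the expectation for compound 4 is a step of a 2.6-fold higher number from compound 3 to compound 4 (0.41 log units; beyond the scatter) in this assay, set beside the earlier 2.9-fold higher number from compound 1 to compound 2 (0.46 log units; beyond the scatter) and resting on that single measured step. Compound 4 is therefore estimated at 700 nM, expected to fall between 350 nM and 1400 nM.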

Compound 4, half-maximal inhibitory concentration: 340 nM
For compound 4 the middle estimate is 2.1-fold (0.31 log units) above the measured one; the measured number lies below the stated range.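

On the core of compound 3, the methyl step in this assay gives a 1.3-fold higher number from compound 3 to compound 4 (0.10 log units; within the scatter), so phenyl to 4-methylphenyl no longer reads as a clear step there, yet the gap to the earlier step stays inside what two such steps can scatter: the same change on two cores in this assay, a 2.9-fold higher number (0.46 log units; beyond the scatter) from compound 1 to compound 2 and a 1.3-fold higher number (0.10 log units; within the scatter) from compound 3 to compound 4, 2.3-fold (0.36 log units) apart, within the scatter of two such steps. The ring-size change reads the same way on the methyl-bearing core, with a 1.0-fold lower number from compound 2 to compound 4 (0.01 log units; within the scatter), set against its earlier step: the same change on two cores in this assay, a 2.3-fold higher number (0.35 log units; beyond the scatter) from compound 1 to compound 3 and a 1.0-fold lower number (0.01 log units; within the scatter) from compound 2 to compound 4, 2.3-fold (0.36 log units) apart, within the scatter of two such steps. For the compounds shown here, the four compounds therefore show neither that either change carries over at its full size nor that its size depends on the core, and with only two instances of each change, no firm size can be given for either.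

On these data alone, whether the same picture holds for other groups on the phenyl, such as chloro or methoxy, stays open. Also open, as far as these compounds go, are other amines at the end of the chain, such as morpholine or dimethylamine, and a longer chain to the amine.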